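From Bromo to Chloro on the Phenoxy Ring

The source may report more compounds than this note shows. Statements on the series, on what has been measured and on what is new or still open speak of the compounds shown alone.

Measured so far:
- compound 1 `NC1=NC2(CCOCC2)N(OCCCOc2ccc(Cl)cc2)C(N)=N1`: "not determined" (no result reported)
- compound 2 `NC1=NC2(CCOCC2)N(OCCCOc2cccc(Br)c2)C(N)=N1`: 85.8%

In an assay on isolated protein for inhibition of Dihydrofolate reductase (Homo sapiens), read by spectrophotometry, using NADPH, with stated times of 5 s and 6 min, tested at 50 uM (on this read-out higher numbers stand for a stronger effect at the one concentration tested and lower numbers for a weaker effect), compound 2 gives 85.8%. In this assay, for the measured compounds named here, compound 1 is recorded as "not determined" (no result reported), so compound 2 stands as the only measured value in this assay, with nothing beside it to rank it against. Going by the values given here, no step between two measured compounds is available, and so the effect of any single structural change on this read-out is unknown from the data themselves.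

Compound 3 `NC1=NC2(CCOCC2)N(OCCCOc2cccc(Cl)c2)C(N)=N1` is the next compound to be tested. It differs from compound 2 by chloro in place of bromo on an aromatic carbon. With one halogen exchanged for another at the same place, the step of a number 5.8 percentage points lower from compound 2 to compound 3 (within the scatter) is expected to be small, with no change beyond the usual scatter in this assay. Compound 3 is therefore estimated to give 80%, with a plausible range from 62% to 92%.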

Compound 3, a percentage reported as inhibition, at one concentration (the size of the read-out at that concentration, not a potency): 85.8%
The estimate for compound 3 lay 5.8 percentage points below the measured number; the measured number falls inside the stated range.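

In this assay, for the compounds shown here, chloro in place of bromo brings no change at the digits printed from compound 2 to compound 3 (within the scatter), which is the first step that can be read between two measured compounds. Going by these compounds alone, at this place on the ring, on an aromatic carbon meta to a large group, the read-out at the one concentration tested therefore does not separate the two halogens, although it gives no potency for either compound. Nothing measured here speaks to what lies behind this result.

From the compounds shown here alone, whether a fluoro, a methyl, a methoxy or a nitrile at the same place would also leave the read-out unchanged remains open. The step to compound 1, which carries its chloro elsewhere on the ring, cannot be read, so the role of the halogen's place on the ring is also unresolved.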